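The compounds below may be only part of what the source reports. "The series", "measured", "known", "first", "only" and "open" are said of these compounds alone.

Compound 1: `N=C(N)NCCC[C@H](NC(=O)CN(c1nc(Cl)nc2[nH]cnc12)C1CC1)C(=O)OCc1ccccc1` — 30.6% in a functional assay on the whole organism (Tail, strain ICR) with Mus musculus as the target, in the tail flick test, with a stated time of 60 min, at a dose of 25 umol/kg by the oral route; on this read-out lower numbers stand for a weaker effect and higher numbers for a stronger effect at the one dose given.
Compound 2: `CC[C@H](C)[C@H](NC(=O)CN(c1nc(Cl)nc2[nH]cnc12)C1CC1)C(=O)OCc1ccccc1` — 40.6% in this assay.
Compound 3: `O=C(O)C[C@H](NC(=O)CN(c1nc(Cl)nc2[nH]cnc12)C1CC1)C(=O)O` — 38.9% in this assay.

All three compounds share the same core and differ only in the side chain on the saturated chain carbon bound to an amide-type nitrogen and a carbonyl carbon. Compound 3 sits among them with a number close to compound 2 and a little further from compound 1, but every gap between the three values lies within the scatter of repeated measurements, so no order among them can be read from the numbers.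

Compound 4, `O=C(O)CNC(=O)CN(c1nc(Cl)nc2[nH]cnc12)C1CC1`, has not yet been measured in this assay. It is reached from compound 3 by hydrogen in place of carboxymethyl on a saturated chain carbon bound to an amide-type nitrogen and a carbonyl carbon. Among the compounds with values here, the one measured step that bears on this place is the swap at the same carbon from compound 1 to compound 2, which gave a number 10 percentage points higher from compound 1 to compound 2 (within the scatter). Within the data shown here, since the only comparable change at this position stayed within the scatter, the expected step from compound 3 to compound 4 is a number 2.9 percentage points lower from compound 3 to compound 4 (within the scatter), meaning no change beyond the scatter is anticipated. Compound 4 is therefore estimated at 36%, with a range from 20% to 52%.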

Compound 4, a percentage reported as activity, at one dose (the size of the read-out at that dose, not a potency): 38.9%
Compound 4: middle estimate off by 2.9 percentage points, on the low side; the measured number falls inside the stated range.
By their numbers in this assay, from the lowest: compounds 1, 3, 4 and 2 (each within the scatter of the next).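

Hydrogen in place of carboxymethyl on a saturated chain carbon bound to an amide-type nitrogen and a carbonyl carbon gave no change at the digits printed from compound 3 to compound 4 (within the scatter) in this assay. The earlier step only exchanged one side chain for another at this carbon, whereas this one removes the side chain altogether, and the read-out at the one dose given still stays within the scatter. So, among the compounds shown, the carboxymethyl group is not required for the effect seen at this dose, and nothing in the data given accounts for this result.

On these data alone, it remains open whether a phenyl ring or a primary amine on this carbon would move the number beyond the scatter. As far as these compounds go, how compound 4 would behave at other doses also stays open.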